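Dihalophenyl sulfonyl replaces methoxyphenyl on a piperidinyl-piperidine sulfonamide

The compounds below may be only part of what the source reports. "The series", "measured", "known", "first", "only" and "open" are said of these compounds alone.

Compound 1 `CC1CCN(C2CCN(S(=O)(=O)c3cnc(Cl)s3)CC2)CC1` carries a 2-chloro-1,3-thiazol-5-yl group on the sulfonyl sulfur, and in a functional assay on DLD-1 cells (Homo sapiens) for antiproliferative activity, read by CellTiter-Glo, with a stated time of 72 h (a higher number here means a weaker inhibitor, a lower number a stronger inhibitor), compound 1 gives 1800 nM. Compound 2 `COc1cccc(S(=O)(=O)N2CCC(N3CCC(C)CC3)CC2)c1` differs from it only by a 3-methoxyphenyl in place of that thiazolyl group. In this assay compound 2 gives > 5000 nM, which is a limit of the assay rather than a number, and the corresponding step of an at least 2.7-fold higher number from compound 1 to compound 2 (0.44 log units; beyond the scatter) is therefore also only a lower bound on its size, as the evidence the limit of > 5000 nM in this assay, at which 1 of the 2 values shown sits, makes plain. Compound 3 `CC1CCN(C2CCN(S(=O)(=O)c3ccc(Br)c(Cl)c3)CC2)CC1` takes the next step: 4-bromo-3-chlorophenyl in place of 3-methoxyphenyl on a sulfonyl sulfur. Within the data shown here, the one measured step shows that the aromatic group on the sulfonyl sulfur matters for this assay, and that a chlorine-bearing aromatic ring in compound 1 sits at 1800 nM. Since compound 2 is known only as a limit, the size of the step to compound 3 is uncertain, but a return toward the range of compound 1 is expected, as an at least 1.6-fold lower number from compound 2 to compound 3 (0.22 log units; that floor lies within the scatter). Compound 3 is therefore estimated at 3000 nM, with a range from 800 nM to 15000 nM.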

Compound 3, half-maximal inhibitory concentration: 12 nM
For compound 3 the middle estimate is 250-fold (2.40 log units) above the measured one; measured number below the stated range.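

On the sulfonyl sulfur, the change to 4-bromo-3-chlorophenyl gives a 150-fold lower number from compound 1 to compound 3 (2.18 log units; beyond the scatter) in this assay, so the aromatic group at this place can move the read-out far more than the step between compound 1 and compound 2 had shown. Compound 1 and compound 3 both carry chlorine on their aromatic group and still lie far apart, which means that chlorine on that group does not by itself set the level reached by compound 3, and against the methoxy-bearing ring the change gives an at least 410-fold lower number from compound 2 to compound 3 (2.61 log units; beyond the scatter), a size that is only a floor. Compound 2 stands at > 5000 nM, which is a limit of the assay and not a number: the limit of > 5000 nM in this assay, at which 1 of the 3 values shown sits.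

The bromine and the chlorine enter together in compound 3, so the compounds shown do not separate their shares, and it remains open how 4-bromophenyl or 3-chlorophenyl alone would compare on the sulfonyl sulfur. All three compounds also share the same core, which leaves open whether the value of compound 3 would hold with another group on that core, such as a carboxylic acid or a longer chain.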